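Triazole series: aryl replaces benzyloxy on the triazole carbon

The source may report more compounds than this note shows. Statements on the series, on what has been measured and on what is new or still open speak of the compounds shown alone.

Measured compounds in this set:
compound 1 `Cc1ccc(OCc2cn(-c3ccc(NS(C)(=O)=O)c(Oc4ccccc4)c3)nn2)cc1` with 8200 nM
compound 2 `CS(=O)(=O)Nc1ccc(-n2cc(OCc3ccccc3)nn2)cc1Oc1ccccc1` with 10700 nM
compound 3 `CS(=O)(=O)Nc1ccc(-n2cc(COc3ccc4ccccc4c3)nn2)cc1Oc1ccccc1` with 9100 nM

All three numbers were obtained in a functional assay on DU-145 cells (Homo sapiens) for inhibition, read by MTT assay, with a stated time of 48 h; on this read-out higher numbers stand for weaker inhibition and lower numbers for stronger inhibition. Compound 2 has the highest of the three numbers, but its distance to compound 3 and to compound 1 lies inside the usual spread of repeated measurements, so no ordering among the three is supported. The two measured steps that start from compound 1 confirm this: a 1.3-fold higher number from compound 1 to compound 2 (0.12 log units; within the scatter), and a 1.1-fold higher number from compound 1 to compound 3 (0.05 log units; within the scatter). Neither change to the group on the triazole carbon moved the read-out beyond the scatter.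

The next compound is compound 4 `Cc1ccc(-c2cn(-c3ccc(NS(C)(=O)=O)c(Oc4ccccc4)c3)nn2)cc1`. It differs from compound 2 in one place: 4-methylphenyl in place of benzyloxy on an aromatic carbon. Here the oxygen link of the benzyloxy group is removed and an aromatic ring is attached directly; the measured steps varied the aryl part and the oxygen-containing linker but never removed the oxygen altogether, so they bear on this change only loosely. As they were all small, no step beyond the scatter is expected, and the estimated step from compound 2 is a 1.1-fold lower number from compound 2 to compound 4 (0.03 log units; within the scatter). Compound 4 is therefore estimated at 10000 nM in this assay, with a range from 4000 nM to 25000 nM.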

Compound 4, half-maximal inhibitory concentration: 11200 nM
Compound 4: the middle estimate sits 1.1-fold (0.05 log units) below what was measured; the range from low to high includes it.
By their numbers in this assay, from the lowest: compounds 1, 3, 2 and 4 (each within the scatter of the next).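

In this assay the series shows a 1.0-fold higher number from compound 2 to compound 4 (0.02 log units; within the scatter) and a 1.4-fold higher number from compound 1 to compound 4 (0.14 log units; within the scatter) when the oxygen-containing link is removed altogether and 4-methylphenyl sits directly on the aromatic carbon of the triazole. Earlier steps varied the aryl part and the linker but always kept an oxygen, whereas this result shows that losing the oxygen, and with it the one hydrogen-bond acceptor counted for benzyloxy, also gives no step beyond the scatter. Benzyloxy, (4-methylphenoxy)methyl and 4-methylphenyl therefore cannot be told apart at this position, and nothing measured here explains that flat read-out.

All groups shown at this carbon are uncharged and carry a carbon-only aromatic ring, so it remains open whether an amine, a carboxylic acid or a longer chain at the same position would give a step beyond the scatter. The compounds shown also keep the rest of the core constant, leaving open how replacing the methanesulfonamide or the phenoxy group would read out.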